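The source may report more compounds than this note shows. Statements on the series, on what has been measured and on what is new or still open speak of the compounds shown alone.

Compound 1 `Cc1cc(/C=C2\SC(=S)N(c3ccccc3)C2=O)c(C)n1-c1ccc(O)c(C(=O)O)c1` in an ADME assay on MT2 cells (Homo sapiens) for cytotoxicity, read by XTT assay, with a stated time of 4 days (a higher number here means that more compound is tolerated, a lower number that less compound is tolerated), reaches only a limit of the assay, > 100000 nM.
Compound 2 `Cc1cc(/C=C2\SC(=S)N(Cc3ccc(Br)cc3)C2=O)c(C)n1-c1ccc(O)c(C(=O)O)c1` gives in this assay 94400 nM.
Compound 3 `Cc1cc(/C=C2\SC(=S)N(Cc3cccc(C(F)(F)F)c3)C2=O)c(C)n1-c1ccc(O)c(C(=O)O)c1` gives in this assay 26300 nM.

Among the two compounds with a measured number, compound 3 has the lowest, so it is the one that is tolerated least; the gap to its nearest neighbour is a 3.6-fold lower number from compound 2 to compound 3 (0.56 log units; beyond the scatter). Compound 4 `Cc1cc(/C=C2\SC(=S)N(Cc3ccccc3Br)C2=O)c(C)n1-c1ccc(O)c(C(=O)O)c1` differs from compound 3 in one place: 2-bromophenyl in place of 3-(trifluoromethyl)phenyl on a saturated chain carbon bound to an amide-type nitrogen in a ring. The measured step that bears on this is the one in which a bromine-bearing ring gave way to a trifluoromethyl-bearing ring, a 3.6-fold lower number from compound 2 to compound 3 (0.56 log units; beyond the scatter); the present change runs the other way, though the bromine now sits in a different position on the ring. The step of an at least 1.0-fold lower number from compound 1 to compound 2 (0.02 log units; that floor lies within the scatter) adds that the earlier bromobenzyl compound sat close to the limit. A modest rise in this assay, roughly reversing that step, is therefore expected: a 2.7-fold higher number from compound 3 to compound 4 (0.43 log units; beyond the scatter). Compound 4 is estimated at 70000 nM, with a range from 25000 nM to 200000 nM.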

Compound 4, half-maximal cytotoxic concentration: 25700 nM
Compound 4: the middle estimate sits 2.7-fold (0.44 log units) above what was measured; the range from low to high includes it.
By their numbers in this assay, from the lowest: compounds 4 and 3 (each within the scatter of the next); then compound 2. At a limit, above all of these: compound 1.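

In this assay, the position of the bromine on the benzyl group turns out to matter, since 2-bromophenyl and 4-bromophenyl on the same saturated chain carbon give a 3.7-fold lower number from compound 2 to compound 4 (0.57 log units; beyond the scatter) and so do not behave alike. Compounds 3 and 4, with different groups at this place, cannot be told apart, with a 1.0-fold lower number from compound 3 to compound 4 (0.01 log units; within the scatter) lying within the scatter, so among the three benzyl compounds only compound 2 stands apart. Compound 1 holds only a limit of the assay, so an at least 3.8-fold lower number from compound 1 to compound 4 (0.59 log units; beyond the scatter) is a floor and not a measured size.

From the compounds shown here alone, whether the position or the group itself sets the number remains open, as a 3-bromobenzyl or a 4-(trifluoromethyl)benzyl group could separate the two. An unsubstituted benzyl group, or a longer chain carrying the same rings, would show how much the ring substituent contributes at all.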